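Removing One Methoxymethyl Group: An Expected Step in Cytotoxicity

The compounds below may be only part of what the source reports. "The series", "measured", "known", "first", "only" and "open" are said of these compounds alone.

Of the compounds shown here, three have been measured in a functional assay on A549 cells (Homo sapiens) for cytotoxicity, read by resazurin assay, with a stated time of 72 h; a lower number here means a stronger inhibitor, a higher number a weaker inhibitor. Compound 1 `COc1cc(OC)c(C(C)=O)c(OC)c1` gives 9800 nM in this assay, and compound 2 `COCOc1cc(OC)cc(OC)c1C(C)=O` gives 16900 nM. Compound 1 arises from compound 2 by a single change, (hydrogen in place of methoxy on a saturated chain carbon bound to an oxygen on an aromatic ring), and that change made a step of a 1.7-fold lower number from compound 2 to compound 1 (0.24 log units; within the scatter). Compound 3 `COCOc1cc(OCOC)c(C(=O)/C=C/c2ccccc2)c(OCOC)c1` gives 8400 nM in this assay; how its core differs from that of compound 2 is not broken down here. The values of compound 3 and compound 1 lie within the scatter of each other, as do those of compound 3 and compound 2, so no order among the three can be read from these numbers.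

Compound 4 `COCOc1cc(OC)c(C(=O)/C=C/c2ccccc2)c(OCOC)c1` has not yet been measured in this assay. It differs from compound 3 by hydrogen in place of methoxy on a saturated chain carbon bound to an oxygen on an aromatic ring, the same change, at the same kind of place, as that from compound 2 to compound 1. Among the measured compounds shown here, the only guide is the earlier step, a 1.7-fold lower number from compound 2 to compound 1 (0.24 log units; within the scatter), which stayed within the scatter. Compound 4 is therefore expected to show a step of about a 1.4-fold lower number from compound 3 to compound 4 (0.15 log units; within the scatter), resting on that single precedent. The estimate for compound 4 in this assay is 6000 nM, with a likely range from 2500 nM to 15000 nM.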

Compound 4, half-maximal inhibitory concentration: 4200 nM
The estimate for compound 4 lay 1.4-fold (0.15 log units) above the measured number; the range from low to high includes it.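

In this assay, putting hydrogen in place of methoxy on a saturated chain carbon bound to an oxygen on an aromatic ring gave a step of a 2.0-fold lower number from compound 3 to compound 4 (0.30 log units; within the scatter) on the core of compound 3. Each of the two steps lies within the scatter on its own, so the data do not show that this change has a real effect on either core, and two cores give no basis for a rule across the series. What they do show is that the change carried from the core of compound 2 to the core of compound 3 with no difference in size that can be told apart: the same change on two cores in this assay, a 1.7-fold lower number (0.24 log units; within the scatter) from compound 2 to compound 1 and a 2.0-fold lower number (0.30 log units; within the scatter) from compound 3 to compound 4, 1.2-fold (0.06 log units) apart, within the scatter of two such steps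

The compounds shown carry only methoxymethoxy or methoxy at the oxygens concerned, which leaves open what a free hydroxyl, an amine or a longer chain such as ethoxymethoxy would give at that place. Going by these compounds, whether the step would keep its size on any further core also remains open.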